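The source may hold more compounds than are shown below. What is called first, only, known or untested is meant among the compounds shown, and "the series" means these compounds.

Measured in a physicochemical assay for lipophilicity; on this read-out lower numbers stand for lower lipophilicity and higher numbers for higher lipophilicity:
compound 1 `O=S(=O)(Nc1nccs1)c1ccc2c(c1)OCC[C@@H]2c1ccc(C(F)(F)F)cc1-c1ccc(F)cn1` gives 3.5
compound 2 `O=S(=O)(Nc1nccs1)c1ccc2c(c1)OCC[C@@H]2c1ccc(C(F)(F)F)cc1-n1ccnn1` gives 2.3

Compound 2 stands lowest of the two numbers shown; the single measured step is a number 1.20 log units lower from compound 1 to compound 2 (beyond the scatter), a large one. The next step goes to compound 3 `O=C1COCCN1c1cc(C(F)(F)F)ccc1[C@H]1CCOc2cc(S(=O)(=O)Nc3nccs3)ccc21`, with the change (3-oxomorpholin-4-yl in place of 1H-1,2,3-triazol-1-yl on an aromatic carbon). Within the data shown here, that measured step exchanged a different group at the same aromatic carbon and does not cover the swap of 1H-1,2,3-triazol-1-yl for 3-oxomorpholin-4-yl; no measured pair does. The expected step in this assay is therefore a number 0.10 log units lower from compound 2 to compound 3 (within the scatter), not beyond the scatter in either direction. Compound 3 is estimated at 2.2, range 1.6 to 2.8.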

Compound 3, distribution coefficient: 1.8
Compound 3: the middle estimate sits 0.40 log units above what was measured; the measured number falls inside the stated range.
By their numbers in this assay, from the lowest: compound 3; then compound 2; then compound 1.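

In this assay the change to 3-oxomorpholin-4-yl gives a number 0.50 log units lower from compound 2 to compound 3 (beyond the scatter) and a number 1.70 log units lower from compound 1 to compound 3 (beyond the scatter) at this aromatic carbon. A six-membered non-aromatic ring therefore stands lowest of the three groups compared here, so this position is not limited to the range set by the two aromatic groups. No measurement on hand accounts for these steps.

Which part of 3-oxomorpholin-4-yl carries the step stays open, since the carbonyl and the ring oxygen always appear together. A plain morpholine or an open-chain amide at this carbon would separate them.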